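A few compounds are considered here, and "the series" means these few. Any claim that something is new, unique, unknown or untested is made for them only; others in the source may bear on it.

Compound 1, `O=c1ccn(CCCCCOc2ccc(Cl)cc2)c(=O)[nH]1`, carries a pentyl chain from the uracil nitrogen of the shared core to an aryl ether bearing chloro. In an ADME assay on HEL cells (Homo sapiens) for cytotoxicity (on this read-out lower numbers stand for higher toxicity in this test and higher numbers for lower toxicity in this test), compound 1 is recorded as "not determined" (no result reported), so no number describes where it stands on this read-out. The only companion with a result is compound 2, `O=c1ccn(CCCCCCCCOc2ccc(Br)cc2)c(=O)[nH]1`, whose chain is three carbons longer and whose aryl ring bears bromo instead. In this assay compound 2 is reported only as a limit of the assay, > 100000 nM. The single datum in hand is therefore (the limit of > 100000 nM in this assay, at which 1 of the 2 values shown sits), and nothing measured separates compound 1 from compound 2.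

Compound 3, `Cc1ccc(OCCCCCn2ccc(=O)[nH]c2=O)cc1`, is the not yet measured neighbour of compound 1. The change is methyl in place of chloro on an aromatic carbon; methyl in place of chloro on an aromatic carbon, para to a large group. Among the measured compounds shown here, with no measured step between compound 1 and compound 3, and the one known value sitting at the limit, the expected step in this assay is none beyond the usual scatter. Compound 3 is expected to show a half-maximal cytotoxic concentration of about 100000 nM, estimated to lie between 50000 nM and 300000 nM, most likely again reported as a limit.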

Compound 3, half-maximal cytotoxic concentration: > 100000 nM
Compound 3: a limit, no number; the forecaster's own chance of this, stated with the estimate: 75%; the middle value lies on the limit itself.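

In this assay compound 3 gives > 100000 nM, which is a limit of the assay and not a number. Among the compounds shown here, compound 1 has no result in this assay, so no step between compound 1 and compound 3 can be read. The compounds shown leave open how 4-chlorophenyl and 4-methylphenyl compare on this read-out.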